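This account rests on a few compounds, and the source may have more. Where it says the series, first, only, none or still open, it means among the compounds named here.

Measured so far:
- compound 1 `N=C(N)NCCC[C@H](NC(=O)CN(c1nc(Cl)nc2[nH]cnc12)C1CC1)C(=O)OCc1ccccc1` — 23.2%
- compound 2 `O=C(O)CC[C@H](NC(=O)CN(c1nc(Cl)nc2[nH]cnc12)C1CC1)C(=O)O` — 26.8%
- compound 3 `O=C(CN(c1ncnc2c1ncn2C1CCCCO1)C1CC1)N[C@@H](CO)C(=O)OCc1ccccc1` — 27.8%

In a functional assay on the whole organism (Tail, strain ICR) with Mus musculus as the target, in the tail flick test, with a stated time of 30 min, at a dose of 25 umol/kg by the oral route (a higher number here means a stronger effect of the compound at the dose given, a lower number a weaker effect), compound 1 gives 23.2%, compound 2 gives 26.8% and compound 3 gives 27.8%. Compound 3 carries the highest of the three numbers, but the gaps to compound 2 and to compound 1 both lie within the scatter, so no order among the three can be read from these figures; they sit close together across quite different structures.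

Compound 4 `CSCC[C@H](NC(=O)CN(c1ncnc2c1ncn2C1CCCCO1)C1CC1)C(=O)OCc1ccccc1` has not yet been measured in this assay. The change from compound 3 is (methylsulfanyl)methyl in place of hydroxy on a saturated chain carbon, two bonds along the chain from an amide-type nitrogen and a carbonyl carbon. Within the data shown here, no step between two measured compounds is available to size this kind of change, and the three numbers so far give no sign that the part of the molecule altered here moves the read-out much.

On that basis the step from compound 3 to compound 4 is estimated at a number 0.8 percentage points lower from compound 3 to compound 4 (within the scatter), that is, no change beyond the scatter is expected in either direction. Compound 4 is expected to give 27%, with a range from 15% to 40%.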

Compound 4, a percentage reported as activity, at one dose (the size of the read-out at that dose, not a potency): 30%
Estimate against measurement, compound 4: 3 percentage points below; low and high end bracket the measured number.
By their numbers in this assay, from the lowest: compounds 1, 2, 3 and 4 (each within the scatter of the next).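

In this assay, among these compounds, the step of a number 2.2 percentage points higher from compound 3 to compound 4 (within the scatter) is the first that can be read at this position, on a saturated chain carbon, two bonds along the chain from an amide-type nitrogen and a carbonyl carbon. In this one pair, (methylsulfanyl)methyl in place of hydroxy removes a hydrogen-bond donor and adds heavy atoms, including sulfur, yet the read-out at this dose stays within the scatter. No measurement shown gives a reason for this outcome.

As far as these compounds go, whether an amine, a carboxylic acid or a longer chain at this carbon would leave the read-out equally unmoved remains open. Also open, from the compounds shown here alone, is whether the same change would behave alike on the core of compound 1, and what a single dose conceals about potency.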